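Methylsulfanyl to Vinyl: From Compound 1 to Compound 3

The source may hold more compounds than are shown below. What is called first, only, known or untested is meant among the compounds shown, and "the series" means these compounds.

Measured compounds:
compound 1, `CSCc1cc(C(C)=O)c(O)cc1OCCCCCCC#N`: 64%
compound 2, `CC(=O)c1cc(CC(C)O)c(OCCCCC#N)cc1O`: 6%

Two compounds carry a value in an assay on isolated protein for binding affinity to leukotriene B4 receptor 1 (Homo sapiens), tested at 1 uM; on this read-out higher numbers stand for more inhibition at the one concentration tested (going by the name of the read-out) and lower numbers for less inhibition. Compound 1 gives 64%, and compound 2 gives 6%. Compound 1 therefore stands highest of the two numbers, with compound 2 lying lower by a margin beyond the usual scatter. The two structures differ in more than one place, so nothing beyond what the two values show can be said of that pair.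

Compound 3, `C=CCc1cc(C(C)=O)c(O)cc1OCCCCCCC#N`, is not yet measured in this assay. It derives from compound 1 by a single change: vinyl in place of methylsulfanyl on a saturated chain carbon bound to an aromatic carbon. Among the measured compounds shown here, the change keeps the size of the group and removes only a hydrogen-bond acceptor, and no measured pair in this set isolates such a swap.

The step of a number 9 percentage points lower from compound 1 to compound 3 (within the scatter) is expected to be small, pointing slightly downward but not clearly beyond the scatter. Compound 3 is accordingly estimated to give about 55%, with a range from 30% to 75%.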

Compound 3, a percentage reported as inhibition, at one concentration (the size of the read-out at that concentration, not a potency): 63%
Compound 3: middle estimate off by 8 percentage points, on the low side; the measured number falls inside the stated range.
By their numbers in this assay, from the lowest: compound 2; then compounds 3 and 1 (each within the scatter of the next).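

In this assay, among the compounds shown here, vinyl in place of methylsulfanyl on a saturated chain carbon bound to an aromatic carbon gives a number 1 percentage points lower from compound 1 to compound 3 (within the scatter), and this is the first step in the set that changes one place only. At this place, then, the sulfur and the hydrogen-bond acceptor counted for methylsulfanyl can give way to two carbons and a double bond outside aromatic rings, with the heavy-atom count unchanged and no shift beyond the scatter on the core of compound 1. No measurement at hand explains why the two groups read alike.

On these data alone, it remains open whether an amine or a carboxylic acid on the same saturated chain carbon would leave the number in this range, as both groups compared here carry no hydrogen-bond donor and no net charge. Also open, as far as these compounds go, is which of its several differences goes with the value of compound 2, 6%, and whether a longer or shorter chain than the one ending in the nitrile would matter on its own.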